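Trifluoromethyl for dimethylamino on the aromatic ring

The source may report more compounds than this note shows. Statements on the series, on what has been measured and on what is new or still open speak of the compounds shown alone.

In a functional assay on T47D cells (Homo sapiens) for cytotoxicity, read by MTT assay, with a stated time of 2 days (on this read-out lower numbers stand for stronger inhibition and higher numbers for weaker inhibition), compound 1 `Cc1ccc2nc(-c3ccccc3C(F)(F)F)[nH]c(=O)c2c1` gives > 50000 nM, which is a limit of the assay and not a number. Compound 2 `CCN(CC)c1ccc2nc(-c3ccccc3OC(F)(F)F)[nH]c(=O)c2c1` gives 1670 nM. Compound 3 `CCN(CC)c1ccc2nc(-c3ccccc3N(C)C)[nH]c(=O)c2c1` gives 2210 nM, so the two numbers stand within the scatter of each other. Going by the values given here, the one measured step, a 1.3-fold higher number from compound 2 to compound 3 (0.12 log units; within the scatter), put dimethylamino in place of trifluoromethoxy on an aromatic carbon.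

Compound 4 `CCN(CC)c1ccc2nc(-c3ccccc3C(F)(F)F)[nH]c(=O)c2c1` now puts trifluoromethyl in place of dimethylamino at that same carbon of a six-membered aromatic ring of carbon only, ortho to a large group: trifluoromethyl in place of dimethylamino on an aromatic carbon. Among the compounds with values here, only one measured step changes a group at this place, and it stayed within the scatter. On the evidence of compound 3 at 2210 nM, no change beyond the scatter is expected here, though a single step is thin support. The expected size is a 1.1-fold higher number from compound 3 to compound 4 (0.05 log units; within the scatter). For compound 4 the estimated value is 2500 nM, with an expected range from 900 nM to 8000 nM.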

Compound 4, half-maximal inhibitory concentration: 2550 nM
Compound 4: middle estimate off by 1.0-fold (0.01 log units), on the low side; the range from low to high includes it.
By their numbers in this assay, from the lowest: compounds 2, 3 and 4 (each within the scatter of the next). At a limit, above all of these: compound 1.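

In this assay, the trifluoromethyl, dimethylamino and trifluoromethoxy compounds now form a complete set of three at this aromatic carbon, and both new steps stay within the scatter: a 1.2-fold higher number from compound 3 to compound 4 (0.06 log units; within the scatter) and a 1.5-fold higher number from compound 2 to compound 4 (0.18 log units; within the scatter). Going by these compounds alone, with trifluoromethyl held constant, the other substituent gives the first step beyond the scatter, with diethylamino in place of methyl: an at least 19-fold lower number from compound 1 to compound 4 (1.29 log units; beyond the scatter). The value of compound 1 is a limit and not a number: the limit of > 50000 nM in this assay, at which 1 of the 4 values shown sits.

The compounds shown leave open whether a carboxylic acid or a primary amine at the trifluoromethyl carbon would also stay within the scatter. They also leave open how a dimethylamino group or a longer chain would compare with diethylamino at the other place.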